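Carbamate aryl change from compound 2 to compound 3

A few compounds are considered here, and "the series" means these few. Any claim that something is new, unique, unknown or untested is made for them only; others in the source may bear on it.

Measured compounds:
compound 1 `COc1cccc(NC(=O)Oc2cc(=O)n(CCCO)c3c2CC(CC=C(C)C)C(C)(C)C3)c1` — 16.2%
compound 2 `COc1ccccc1NC(=O)Oc1cc(=O)n(CCCO)c2c1CC(CC=C(C)C)C(C)(C)C2` — 71.1%

For the measured compounds named here, in a functional assay on PANC-1 cells (Homo sapiens) for inhibition, read by MTT assay, with a stated time of 24 h, tested at 10 uM (on this read-out higher numbers stand for more inhibition at the one concentration tested (going by the name of the read-out) and lower numbers for less inhibition), compound 2 gives 71.1% and stands highest of the two numbers; the only measured step is a number 54.9 percentage points higher from compound 1 to compound 2 (beyond the scatter), a 2-methoxyphenyl in place of a 3-methoxyphenyl on an amide-type nitrogen. Compound 3 `CC(C)=CCC1Cc2c(OC(=O)Nc3ccc(F)c(Cl)c3)cc(=O)n(CCCO)c2CC1(C)C` differs from compound 2 by 3-chloro-4-fluorophenyl in place of 2-methoxyphenyl on an amide-type nitrogen. Going by the values given here, no measured step covers this change; the one step shows only that the substitution pattern on this aryl group shifts the read-out strongly, so a step of uncertain direction is expected. Compound 3 is estimated at 45% (range 10% to 80%), an expected a number 26.1 percentage points lower from compound 2 to compound 3 (beyond the scatter).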

Compound 3, a percentage reported as inhibition, at one concentration (the size of the read-out at that concentration, not a potency): 79.8%
Beside the measured number, compound 3's estimate is 34.8 percentage points below it, and the stated range covers the measured number.
By their numbers in this assay, from the lowest: compound 1; then compounds 2 and 3 (each within the scatter of the next).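

In this assay, a dihalogenated aryl group on the amide-type nitrogen holds the read-out at the level of the 2-methoxyphenyl group: 3-chloro-4-fluorophenyl gives a number 8.7 percentage points higher from compound 2 to compound 3 (within the scatter). Against 3-methoxyphenyl, the same group gives a number 63.6 percentage points higher from compound 1 to compound 3 (beyond the scatter), leaving compound 1 as the only low value among the three aryl groups. No evidence bears on why these aryl groups differ. On these data alone, whether 3-chlorophenyl or 4-fluorophenyl alone matches compound 3 stays open. So does the effect of a pyridine ring or a cyclohexyl group on this nitrogen.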